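From an aminophenyl to a biphenyl in a cytotoxicity screen

The compounds below may be only part of what the source reports. "The series", "measured", "known", "first", "only" and "open" are said of these compounds alone.

Going by the values given here, compound 2 `COC(=O)c1ccc(NCc2cncn2Cc2ccccc2N)cc1-c1ccccc1` is the only member of this small set with a numerical reading: in a toxicity assay on NIH3T3 cells (Mus musculus) for cytotoxicity, read by resazurin assay (a lower number here means that less compound is needed, a higher number that more compound is needed for the effect), compound 2 gives 25000 nM. Compound 1 `COC(=O)c1ccc(NCc2cncn2Cc2cccc(Br)c2)cc1-c1ccccc1` has in this assay only a limit of the assay, > 10000 nM. The step that the limit leaves unreadable from compound 1 to compound 2 therefore cannot be sized, because of the limit of > 10000 nM in this assay, at which 1 of the 2 values shown sits. Compound 3 `COC(=O)c1ccc(NCc2cncn2Cc2ccc(-c3ccccc3)cc2)cc1-c1ccccc1`, not yet measured, differs from compound 2 by 4-phenylphenyl in place of 2-aminophenyl on a saturated chain carbon bound to an aromatic nitrogen. Among the compounds with values here, no measured step bears on this change: the only pair that alters the same position, compound 1 to compound 2, is left unreadable by the limit. With nothing to point either way, the expectation in this assay is no step beyond the usual scatter, estimated as a 1.3-fold lower number from compound 2 to compound 3 (0.10 log units; within the scatter). For compound 3 the expected value in this assay is 20000 nM, within an estimated range of 7000 nM to 60000 nM.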

Compound 3, half-maximal effective concentration: > 1000 nM
Compound 3 gave a limit, no number; the forecaster's own chance of this, stated with the estimate: 40%; the middle value does not contradict the limit.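

In this assay compound 3 gives > 1000 nM as a limit of the assay, not a number, so the steps joining compound 3 to compound 1 and compound 2 cannot be read. The compounds shown leave open how 3-bromophenyl, 2-aminophenyl and 4-phenylphenyl compare in this assay at this position.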